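The source may report more compounds than this note shows. Statements on the series, on what has been measured and on what is new or still open speak of the compounds shown alone.

Measured so far in a functional assay on the whole organism (strain Swiss albino) for inhibition, with Mus musculus as the target, in the writhing test, with stated times of 60 min and 15 min, at a dose of 100 mg/kg by the oral route; on this read-out higher numbers stand for more inhibition at the one dose given (going by the name of the read-out) and lower numbers for less inhibition:

- compound 1 `COc1cc2c(cc1OC)C(CC(=O)O)CC2`: 44%
- compound 2 `COc1cc2c(cc1OC)C(CC(=O)N1CCCCC1)CC2`: 44.7%

Among the measured compounds shown here, compound 2 stands alongside compound 1; the single measured step, a number 0.7 percentage points higher from compound 1 to compound 2 (within the scatter), leaves the two values indistinguishable. Compound 3 `COc1cc2c(cc1OC)C(CC(=O)NCCO)CC2` is the next member and has not yet been measured in this assay. ((2-hydroxyethyl)amino in place of piperidin-1-yl on a carbonyl carbon). For the measured compounds named here, the one measured step bears on this only loosely: it exchanged hydroxy for piperidin-1-yl on the carbonyl carbon and gave a number 0.7 percentage points higher from compound 1 to compound 2 (within the scatter), a move of no consequence. Going by the values given here, no measured compound carries (2-hydroxyethyl)amino, so the series offers no direction for this replacement. Accordingly no movement beyond the scatter is expected for compound 3 in this assay, an estimated step of a number 0.7 percentage points lower from compound 2 to compound 3 (within the scatter). The estimate for compound 3 in this assay is 44%, with a range from 30% to 58%.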

Compound 3, a percentage reported as inhibition, in the whole organism at one dose (the size of the read-out at that dose, not a potency): 29.8%
For compound 3 the middle estimate is 14.2 percentage points above the measured one, outside the stated range (below it).
By their numbers in this assay, from the lowest: compound 3; then compounds 1 and 2 (each within the scatter of the next).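

In this assay the group on the carbonyl carbon turns out to matter: (2-hydroxyethyl)amino in place of piperidin-1-yl gives a number 14.9 percentage points lower from compound 2 to compound 3 (beyond the scatter), and in place of hydroxy it gives a number 14.2 percentage points lower from compound 1 to compound 3 (beyond the scatter). The earlier exchange of hydroxy for piperidin-1-yl therefore did not show that this position is indifferent to its substituent, since two quite different groups stand level there while a third falls away. Nothing available here accounts for the lower number of compound 3.

Still open, going by these compounds, is whether the loss follows the terminal hydroxyl of the chain or the amide hydrogen; ethylamino or 2-methoxyethylamino on the same carbonyl carbon would separate the two. Also open, on these data alone, is how a ring such as morpholin-4-yl would compare with piperidin-1-yl at this position.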